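A Chloro Added to a Benzyl Group in an Inactive Series

The source may hold more compounds than are shown below. What is called first, only, known or untested is meant among the compounds shown, and "the series" means these compounds.

Three compounds have been tested in an assay on HL-60 cells for agonist activity at N-formyl peptide receptor 3 (Homo sapiens), read by calcium flux; on this read-out lower numbers stand for an effect already at smaller amounts and higher numbers for an effect only at larger amounts of compound:
Compound 1 `COc1ccc(Cc2cc(-c3ccc(Cl)cc3)nn(CC(=O)Nc3ccc(Br)cc3)c2=O)cc1` reaches only the assay limit, > 50000 nM.
Compound 2 `Cc1cc(Cc2ccccc2)c(=O)n(CC(=O)Nc2ccc(Br)cc2)n1` also reaches only the assay limit, > 50000 nM.
Compound 3 `Cc1cc(Cc2ccccc2)c(=O)n(CC(=O)Nc2ccc(F)cc2)n1` likewise reaches only the assay limit, > 50000 nM.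

Compound 2 thus stands at the limit of > 50000 nM in this assay, at which 3 of the 3 values shown sit, with no number of its own. Among the measured compounds shown here, the step that the two limits leave unreadable from compound 2 to compound 3, so the one measured change teaches nothing about size or direction. Compound 4 `Cc1cc(Cc2cccc(Cl)c2)c(=O)n(CC(=O)Nc2ccc(Br)cc2)n1` differs from compound 2 by chloro in place of hydrogen on an aromatic carbon. For the measured compounds named here, no measured step bears on this change, and every value so far sits at the limit. Compound 4 is therefore expected to remain at or near the limit, estimated at 80000 nM, between 20000 nM and 300000 nM. The expected step from compound 2 to compound 4 is a step that the limit leaves unreadable from compound 2 to compound 4.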

Compound 4, half-maximal effective concentration: > 50000 nM
Compound 4 gave a limit, no number; the forecaster's own chance of this, stated with the estimate: 85%; the middle value lies beyond the limit too.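

Compound 2 and compound 4 both give only a limit, so no step can be read between them: the limit of > 50000 nM in this assay, at which 4 of the 4 values shown sit.

The compounds shown leave open whether any change to this shared core brings a readable value, and what the chloro contributes.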